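The source may hold more compounds than are shown below. What is called first, only, known or untested is meant among the compounds shown, and "the series" means these compounds.

Compound 1 `Cc1n[nH]c2nnc(N)c-2c1C`: "not determined" (no result reported)
Compound 2 `Nc1nn(Cc2ccccc2)c2nnc(-c3ccccc3)c(-c3ccccc3)c12`: > 100000 nM
Compound 3 `Nc1[nH]nc2nnc(-c3ccco3)cc12`: > 100000 nM

These compounds belong to a series examined in a functional assay on PC-3 cells (Homo sapiens) for cytotoxicity; a lower number here means a stronger inhibitor, a higher number a weaker inhibitor. Compound 2 gives > 100000 nM, which is a limit of the assay and not a number. Compound 3 gives > 100000 nM, which is also a limit. Compound 1 has no result, being "not determined" (no result reported). Compound 2 therefore stands at the limit of > 100000 nM in this assay, at which 2 of the 3 values shown sit. Compound 4 `Nc1nn(COCCO)c2nnc(-c3ccccc3)c(-c3ccccc3)c12` has 2-hydroxyethoxy in place of phenyl on a saturated chain carbon bound to an aromatic nitrogen. For the measured compounds named here, no measured step shows what such a change does, so no shift beyond the scatter is expected, and another limit is the likeliest report. The expected step is a number no higher from compound 2 to compound 4 (the limit leaves the size open). For compound 4 the estimate is 100000 nM, with an expected range of 40000 nM to 200000 nM.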

Compound 4, half-maximal inhibitory concentration: > 100000 nM
Compound 4 gave a limit, no number; the forecaster's own chance of this, stated with the estimate: 85%; the middle value sits exactly at the limit.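

For the compounds shown here, compound 2 and compound 4 both gave only a limit in this assay, so no step between them can be read. The compounds shown leave open whether replacing benzyl with (2-hydroxyethoxy)methyl changes the cytotoxic potency at all.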